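The source may report more compounds than this note shows. Statements on the series, on what has been measured and on what is new or still open speak of the compounds shown alone.

Compound 1 `Cc1c(Oc2ccc(OC(F)(F)F)cc2)ccnc1N1CCC(NC(=S)Nc2cccnc2)CC1` was examined in an assay on membranes from brain for binding affinity to Lysophosphatidylserine lipase ABHD12 (Mus musculus), read by fluorescence, with a stated time of 20 min (a higher number here means a weaker inhibitor, a lower number a stronger inhibitor), where compound 1 gives 26 nM. That is the lowest of the three numbers obtained so far. Compound 2 `FC(F)(F)c1ccnc(N2CCC(NC(=S)Nc3cccnc3)CC2)c1Cl` gives 300 nM and compound 3 `S=C(Nc1cccnc1)NC1CCN(c2cc(OCc3ccccc3)ccn2)CC1` gives 2800 nM; both gaps to compound 1 lie beyond the usual scatter, so compound 1 is the strongest inhibitor of the three. Compound 4 `N#Cc1c(Oc2ccc(OC(F)(F)F)cc2)ccnc1N1CCC(NC(=S)Nc2cccnc2)CC1` has not yet been measured. It differs from compound 1 in one place: cyano in place of methyl on an aromatic carbon. Among the compounds with values here, no measured pair shows what this swap does in this assay, so the expectation rests on compound 1 alone. Only a small step is expected a 1.5-fold higher number from compound 1 to compound 4 (0.19 log units; within the scatter), perhaps a slight weakening near the scatter. Compound 4 is therefore estimated at 40 nM, within a range from 10 nM to 160 nM.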

Compound 4, half-maximal inhibitory concentration: 180 nM
Compound 4: middle estimate off by 4.5-fold (0.65 log units), on the low side; measured number outside the range, above it.
By their numbers in this assay, from the lowest: compound 1; then compounds 4 and 2 (each within the scatter of the next); then compound 3.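

This position is not indifferent to what it carries: in this assay, cyano in place of methyl gives a 6.9-fold higher number from compound 1 to compound 4 (0.84 log units; beyond the scatter) on an otherwise unchanged structure. The swap adds one heavy atom and one hydrogen-bond acceptor, and compound 4 is the weaker inhibitor of the pair. Nothing available explains this loss. As far as these compounds go, whether an ethyl or a methoxy group here would match compound 1 remains open. So does whether this swap would weaken inhibition to a similar degree with a different group in place of the 4-(trifluoromethoxy)phenoxy part.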